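The source may report more compounds than this note shows. Statements on the series, on what has been measured and on what is new or still open speak of the compounds shown alone.

Of the compounds shown here, three have been measured in an ADME assay on cells (Homo sapiens) for cytotoxicity, read by polymerase chain reaction, with a stated time of 3 days; a higher number here means that more compound is tolerated, a lower number that less compound is tolerated. Compound 1, with the structure `CNc1ccc2sc(-c3c(Cl)nc(N)nc3N[C@@H]3C[C@H](CO)[C@@H](O)[C@H]3O)nc2c1`, gives 20000 nM, and compound 2, with the structure `CN(C)c1ccc2sc(-c3c(Cl)nc(N)nc3N[C@@H]3C[C@H](CO)[C@@H](O)[C@H]3O)nc2c1`, gives 25000 nM. Within the data shown here, the only single-point step between measured compounds, a 1.3-fold higher number from compound 1 to compound 2 (0.10 log units; within the scatter), is a methyl in place of hydrogen on a nitrogen on an aromatic ring. Compound 3, with the structure `Cc1nc(NCC2CC2)nc(N[C@@H]2C[C@H](CO)[C@@H](O)[C@H]2O)c1-c1nc2ccccc2s1`, gives 8000 nM, which is the lowest of the three numbers; its distance to compound 1 and to compound 2 is in each case beyond the scatter, so compound 3 is the least tolerated of the three.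

Compound 4, with the structure `Cc1nc(Nc2ccccc2)nc(N[C@@H]2C[C@H](CO)[C@@H](O)[C@H]2O)c1-c1nc2ccccc2s1`, differs from compound 3 in one place: phenyl in place of cyclopropylmethyl on a nitrogen on an aromatic ring. Among the measured compounds shown here, no measured step replaces a cyclopropylmethyl by a phenyl; the one step known, from a hydrogen to a methyl on a ring nitrogen, was within the scatter, and it is of a different kind. For the measured compounds named here, with no direct precedent, the expectation is a step of no change at the digits printed from compound 3 to compound 4 (within the scatter) in this assay, that is, no movement beyond the scatter. Compound 4 is therefore expected to give about 8000 nM, estimated between 3000 nM and 20000 nM.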

Compound 4, half-maximal cytotoxic concentration: > 25000 nM
Compound 4 gave a limit, no number; the forecaster's own chance of this, stated with the estimate: 5%; middle value at least 3.1-fold (0.49 log units) away from the limit.
By their numbers in this assay, from the lowest: compound 3; then compounds 1 and 2 (each within the scatter of the next).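

In this assay, phenyl in place of cyclopropylmethyl on a nitrogen on an aromatic ring gives an at least 3.1-fold higher number from compound 3 to compound 4 (0.49 log units; beyond the scatter). Among these compounds, the group on this nitrogen can therefore move the number beyond the scatter, which the one earlier step, a 1.3-fold higher number from compound 1 to compound 2 (0.10 log units; within the scatter), did not show. Compound 4 gives > 25000 nM, which is a limit and not a number, so the step has a lower bound only and its full size cannot be read: the limit of > 25000 nM in this assay, at which 1 of the 4 values shown sits.

This single pair does not separate the effect of the aromatic ring from that of the higher count of heavy atoms, and a cyclohexyl on the same nitrogen would bear on that question. The compounds shown also leave open whether a benzyl or a pyridyl there would behave like the phenyl.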